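The source may report more compounds than this note shows. Statements on the series, on what has been measured and on what is new or still open speak of the compounds shown alone.

Compound 2, with the structure `ClCc1ccccc1Cn1cnc2c(Cl)nc(Cl)nc21`, carries two chloro groups on its fused core together with a chloromethyl group on the benzyl ring. In a functional assay on SNB-19 cells (Homo sapiens) for cytotoxicity, read by sulforhodamine B assay, with a stated time of 48 h (a higher number here means that more compound is tolerated, a lower number that less compound is tolerated), compound 2 gives "not determined" (no result reported), so no single number stands against it and nothing about its own tolerance can be read off. The closest measured relative is compound 1, with the structure `ClCc1ccc(Cn2cnc3c(Cl)ncnc32)cc1`, built on the same fused core with one chloro group and the same chloromethyl benzyl group arranged differently on the benzene ring. In this assay compound 1 gives 89100 nM.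

The step from compound 2 to compound 3 removes one ring substituent: hydrogen in place of chloro on an aromatic carbon. Compound 3, with the structure `ClCc1ccccc1Cn1cnc2c(Cl)ncnc21`, therefore keeps one chloro group on the fused core, as compound 1 does. Since compound 2 has no number, the size and direction of this step in this assay cannot be anchored; the expectation for compound 3 rests on compound 1 alone, whose value of 89100 nM suggests a weakly cytotoxic series. On that basis compound 3 is estimated to give 80000 nM in this assay, within a range from 30000 nM to 200000 nM.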

Compound 3, concentration lethal to 50% of the cells: > 100000 nM
Compound 3 gave a limit, no number (the forecaster's own chance of this, stated with the estimate: 20%); middle value at least 1.2-fold (0.09 log units) from the limit.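

In this assay compound 3 gives > 100000 nM, which is a limit and not a number. Compound 2 has no number, so no step can be read between compound 2 and compound 3. The compounds shown leave open how swapping that chloro group for hydrogen changes the tolerated concentration in this assay.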